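Replacing a Small Ring with Quinoxalinyl at the Ether Carbon

The source may hold more compounds than are shown below. What is called first, only, known or untested is meant among the compounds shown, and "the series" means these compounds.

Of the compounds shown here, two have been measured in a functional assay for inhibition of Polyunsaturated fatty acid 5-lipoxygenase (Homo sapiens); on this read-out higher numbers stand for weaker inhibition and lower numbers for stronger inhibition. Compound 1 `O=C(O)/C=N/OC(c1ccc(OCc2nc3cccnc3s2)cc1)C1CCCCC1` gives 27 nM. Compound 2 `Cc1nc(COc2ccc(C(O/N=C/C(=O)O)C3CCCCC3)cc2)cs1` gives 380 nM, which is the highest of the two numbers, so compound 2 is the weaker inhibitor of the pair. For the measured compounds named here, the one measured step, a 14-fold higher number from compound 1 to compound 2 (1.15 log units; beyond the scatter), shows that shrinking the group on the saturated chain carbon bound to the oxygen on the aromatic ring from the larger two-ring group of compound 1 to the smaller single ring of compound 2 costs a great deal of inhibition.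

Compound 3 `O=C(O)/C=N/OC(c1ccc(OCc2cnc3ccccc3n2)cc1)C1CCCCC1` is not yet measured. It differs from compound 2 in one place: quinoxalin-2-yl in place of 2-methyl-1,3-thiazol-4-yl on a saturated chain carbon bound to an oxygen on an aromatic ring. Going by the values given here, this change goes back to a larger two-ring group at the same place, which is the reverse of the direction taken by the only measured step. Compound 3 is therefore expected to inhibit more strongly than compound 2, with an estimated step of an 8.4-fold lower number from compound 2 to compound 3 (0.93 log units; beyond the scatter) in this assay. For compound 3 the estimated value is 45 nM, with a range from 12 nM to 180 nM.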

Compound 3, half-maximal inhibitory concentration: 25 nM
Compound 3: the middle estimate sits 1.8-fold (0.26 log units) above what was measured, and the stated range covers the measured number.
By their numbers in this assay, from the lowest: compounds 3 and 1 (each within the scatter of the next); then compound 2.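

In this assay, putting quinoxalin-2-yl in place of 2-methyl-1,3-thiazol-4-yl on a saturated chain carbon bound to an oxygen on an aromatic ring gives a 15-fold lower number from compound 2 to compound 3 (1.18 log units; beyond the scatter) and so recovers about as much as the earlier step had lost. This shows that the strong inhibition of compound 1 is not tied to its particular two-ring group: quinoxalin-2-yl has two six-membered rings and no sulfur, whereas the group in compound 1 has a five-membered ring with sulfur, yet the comparison gives a 1.1-fold lower number from compound 1 to compound 3 (0.03 log units; within the scatter) and the two compounds cannot be told apart. Across these three compounds, both two-ring groups give far stronger inhibition than the single ring, but nothing available explains why this is so.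

From the compounds shown here alone, it remains open whether the ring nitrogens of quinoxalin-2-yl contribute, which naphthalen-2-yl, with two six-membered rings of carbon only, could test at the same place. Going by these compounds, it is also open whether a different single ring, such as pyridin-2-yl, would fall as far as 2-methyl-1,3-thiazol-4-yl does.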